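Bromine at the Second Ring of a Diacylhydrazine Agonist

The source may report more compounds than this note shows. Statements on the series, on what has been measured and on what is new or still open speak of the compounds shown alone.

Compound 1 `CC(C)(C)N(NC(=O)c1ccccc1)C(=O)c1ccccc1Cl` gives the lowest of the two numbers measured in an assay on cells for agonist activity at ecdysone receptor (Bombyx mori), read by a luciferase reporter, with a stated time of 24 h (a lower number here means that less compound is needed, a higher number that more compound is needed for the effect), at 75.9 nM. Going by the values given here, its nearest neighbour, compound 2 `COc1ccccc1C(=O)N(NC(=O)c1ccccc1)C(C)(C)C`, gives 525 nM, and the only measured step, a 6.9-fold higher number from compound 1 to compound 2 (0.84 log units; beyond the scatter), concerns a methoxy in place of chloro on the first ring. Among the compounds with values here, compound 3 `CC(C)(C)N(NC(=O)c1ccccc1Br)C(=O)c1ccccc1Cl` differs from compound 1 by bromo in place of hydrogen on an aromatic carbon, on the other ring, so no measured step bears directly on this change. The expected step is therefore uncertain, a 2.0-fold higher number from compound 1 to compound 3 (0.30 log units; within the scatter), with little change beyond the scatter assumed. Compound 3 is estimated at 150 nM, between 40 nM and 600 nM.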

Compound 3, half-maximal effective concentration: 316 nM
Estimate against measurement, compound 3: 2.1-fold (0.32 log units) below, and the stated range covers the measured number.
By their numbers in this assay, from the lowest: compound 1; then compounds 3 and 2 (each within the scatter of the next).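

Among the earlier compounds, only the ring carrying chloro or methoxy differed; turning the other phenyl into 2-bromophenyl shows that this second ring also responds to substitution, with a 4.2-fold higher number from compound 1 to compound 3 (0.62 log units; beyond the scatter). Adding this one bromo group to an otherwise unchanged compound moves the number upward, beyond the scatter. Nothing available here explains this shift.

From the compounds shown here alone, whether the rise is specific to bromo or would follow any group at this place remains open. Fluoro, methyl or an amine here could give a different result.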